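A few compounds are considered here, and "the series" means these few. Any claim that something is new, unique, unknown or untested is made for them only; others in the source may bear on it.

Measured compounds:
- compound 1, `Nc1nc(NC2CC2)c2ncn(/C=C3/CC3(CO)CO)c2n1`: > 300000 nM
- compound 2, `CC(C)CSc1nc(N)nc2c1ncn2/C=C1/CC1(CO)CO`: > 300000 nM

In an ADME assay on HFF cells (Homo sapiens) for cytotoxicity, with a stated time of 8 days (on this read-out higher numbers stand for lower toxicity in this test and lower numbers for higher toxicity in this test), compound 1 gives > 300000 nM, which is a limit of the assay and not a number. In this assay compound 2 gives > 300000 nM, again a limit and not a number. Going by the values given here, compound 2 therefore stands only at a limit, and the one neighbouring value is a limit as well. The step that the two limits leave unreadable from compound 1 to compound 2 cannot be read because the limit of > 300000 nM in this assay, at which 2 of the 2 values shown sit, holds both of its ends.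

Compound 3, `CCCSc1nc(N)nc2c1ncn2/C=C1/CC1(CO)CO`, differs from compound 2 by hydrogen in place of methyl on a saturated chain carbon bound to two saturated chain carbons. Among the compounds with values here, no measured step bears on this change: the only step in hand, a step that the two limits leave unreadable from compound 1 to compound 2, concerns a different position and is itself unreadable. With nothing to suggest a shift, compound 3 is expected to sit where compound 2 sits, and the step of a number no higher from compound 2 to compound 3 (the limit leaves the size open) is expected to be none beyond the scatter, meaning most likely another limit. For compound 3 in this assay the estimate is 300000 nM, with a range from 100000 nM to 900000 nM.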

Compound 3, half-maximal cytotoxic concentration: > 300000 nM
Compound 3: no number, only a limit; the forecaster's own chance of this, stated with the estimate: 85%; the middle value lies on the limit itself.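

In this assay compound 3 gives > 300000 nM, again a limit and not a number. The steps from compound 2 and from compound 1 to compound 3 cannot be read, because all three compounds sit at the same limit: the limit of > 300000 nM in this assay, at which 3 of the 3 values shown sit.

The compounds shown leave open whether cyclopropylamino, isobutylsulfanyl and propylsulfanyl differ at all on this read-out.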